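Taking one chlorine off compound 2

This account rests on a few compounds, and the source may have more. Where it says the series, first, only, none or still open, it means among the compounds named here.

- Compound 1 `O=S(=O)(Nc1ccc(Cl)c(Cl)c1)c1ccc(-c2cnc(C3CC3)o2)cc1`: > 100000 nM (a limit)
- Compound 2 `O=S(=O)(Nc1ccc(Cl)cc1Cl)c1ccc(-c2cnc(C3CC3)o2)cc1`: > 100000 nM (a limit)

Both entries come from a functional assay on cells (leukaemia cell line, Homo sapiens) for inhibition, read by sulforhodamine B assay, with a stated time of 48 h; a higher number here means that more compound is tolerated, a lower number that less compound is tolerated. In that test, compound 2 stands only at a limit, > 100000 nM. Both measured compounds sit at the same point: the limit of > 100000 nM in this assay, at which 2 of the 2 values shown sit.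

Compound 3 `O=S(=O)(Nc1ccccc1Cl)c1ccc(-c2cnc(C3CC3)o2)cc1` comes from compound 2 through one change: hydrogen in place of chloro on an aromatic carbon. The 2,4-dichlorophenyl thus becomes 2-chlorophenyl.

Among the compounds with values here, the one measured step that bears on this is a step that the two limits leave unreadable from compound 1 to compound 2, so it offers no size to carry over. The expectation therefore rests on compound 2, whose limit is > 100000 nM. No step beyond the scatter is expected in this assay, and another limit is the likeliest report. The estimate amounts to an expected a number no higher from compound 2 to compound 3 (the limit leaves the size open). Compound 3 is expected near 100000 nM, with a range of 40000 nM to 200000 nM.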

Compound 3, concentration lethal to 50% of the cells: > 100000 nM
Compound 3 ended at the assay's limit (the forecaster's own chance of this, stated with the estimate: 85%); the middle value sits exactly at the limit.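

Within the data shown here, compound 1, compound 2 and compound 3 all stand only at a limit, so no step among them can be read: the limit of > 100000 nM in this assay, at which 3 of the 3 values shown sit.

The compounds shown leave open whether 3,4-dichlorophenyl, 2,4-dichlorophenyl and 2-chlorophenyl differ at all in this assay.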